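From an Aromatic Ring to Cyclohexyl in Compound 4

The compounds below may be only part of what the source reports. "The series", "measured", "known", "first", "only" and "open" are said of these compounds alone.

In an ADME assay on microsomes from liver (Homo sapiens) for metabolic stability, with a stated time of 10 min (on this read-out higher numbers stand for a more stable compound and lower numbers for a less stable compound), compound 3 (`COc1cccc(F)c1COC(c1ccc([C@]2(S(=O)(=O)c3ccc(F)cc3)CCN(C(=O)[C@H]3CC[C@H](C(=O)O)CC3)C2)cc1)(C(F)(F)F)C(F)(F)F`) gives 82%, the second highest of three measured numbers. Compound 2 (`O=C(O)[C@H]1CC[C@H](C(=O)N2CC[C@](c3ccc(C(OCc4c(F)cccc4Cl)(C(F)(F)F)C(F)(F)F)cc3)(S(=O)(=O)c3ccc(F)cc3)C2)CC1`) stands higher at 100%, while compound 1 (`CC(=O)N1CCC(O)(C(=O)N2CC[C@](c3ccc(C(OCc4c(F)cccc4F)(C(F)(F)F)C(F)(F)F)cc3)(S(=O)(=O)c3ccc(F)cc3)C2)CC1`) stands far lower at 16%.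

Compound 4 (`O=C(O)[C@H]1CC[C@H](C(=O)N2CC[C@](c3ccc(C(OCC4CCCCC4)(C(F)(F)F)C(F)(F)F)cc3)(S(=O)(=O)c3ccc(F)cc3)C2)CC1`) has cyclohexyl in place of the 2-fluoro-6-methoxyphenyl of compound 3, on a saturated chain carbon bound to an oxygen on a saturated carbon: cyclohexyl in place of 2-fluoro-6-methoxyphenyl on a saturated chain carbon bound to an oxygen on a saturated carbon. The aromatic ring is therefore replaced as a whole.

Among the compounds with values here, only one measured step bears on this change: a number 18 percentage points lower from compound 2 to compound 3 (beyond the scatter). That modest step, beyond the scatter, swapped a single group on the same aromatic ring. Within the data shown here, no measured compound has a non-aromatic ring in this place, so the direction is uncertain, but a modest fall is the most likely outcome. The expected step is a number 12 percentage points lower from compound 3 to compound 4 (beyond the scatter). For compound 4, the estimated value in this assay is 70%, within an expected range of 42% to 92%.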

Compound 4, percent of the compound remaining: 92%
Compound 4: middle estimate off by 22 percentage points, on the low side; low and high end bracket the measured number.
By their numbers in this assay, from the lowest: compound 1; then compounds 3, 4 and 2 (each within the scatter of the next, the first and the last beyond it).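

In this assay, the whole aromatic ring at this position can give way to a saturated one with little visible effect: the change to cyclohexyl gives a number 10 percentage points higher from compound 3 to compound 4 (within the scatter), and measured against the chloro-bearing ring it gives a number 8 percentage points lower from compound 2 to compound 4 (within the scatter). Within the data shown here, the earlier step changed only one group on the aromatic ring, whereas these steps show that neither the aromatic ring nor its substituents are needed to stay within the scatter of compound 2 and compound 3 on this read-out. Nothing available explains why the swap of rings leaves the read-out so little changed.

Going by these compounds, it remains open whether a ring carrying nitrogen, such as piperidinyl, or an open hexyl chain would behave like cyclohexyl in this place. Compound 1 differs from these compounds in more than one place, so it cannot show whether cyclohexyl would fit as well on that different acyl side.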